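A few compounds are considered here, and "the series" means these few. Any claim that something is new, unique, unknown or untested is made for them only; others in the source may bear on it.

Two macrocyclic compounds share a large core and differ only in two small groups. Compound 1, `COc1ccc2c(O[C@H]3C[C@H]4C(=O)N(C)CCCC/C=C/[C@@H]5C[C@@]5(C(=O)NS(=O)(=O)C5(C)CC5)NC(=O)N4C3)cc(-c3nc(C(C)C)cs3)nc2c1Br`, was tested in an ADME assay on Huh-7 cells (Homo sapiens) for cytotoxicity, read by colorimetric assay (on this read-out higher numbers stand for lower toxicity in this test and lower numbers for higher toxicity in this test), and gives 51200 nM. Compound 2, `COc1ccc2c(O[C@H]3C[C@H]4C(=O)N(C)CCCC/C=C/[C@@H]5C[C@@]5(C(=O)NS(=O)(=O)C5(C)CC5)NC(=O)N4C3)cc(-c3cc(C(C)C)on3)nc2c1Cl`, carries a chlorine where compound 1 carries a bromine and an isopropyl-substituted oxazole where compound 1 carries an isopropyl-substituted thiazole; in this assay compound 2 gives 75000 nM. Of the two numbers, that of compound 2 is the larger, but the gap to compound 1 lies within the usual scatter, so the two cannot be told apart on toxicity.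

Compound 3, `COc1ccc2c(O[C@H]3C[C@H]4C(=O)N(C)CCCC/C=C/[C@@H]5C[C@@]5(C(=O)NS(=O)(=O)C5(C)CC5)NC(=O)N4C3)cc(-c3csc(C(F)(F)F)n3)nc2c1Cl`, is the next step from compound 2: 2-(trifluoromethyl)-1,3-thiazol-4-yl in place of 5-isopropyl-1,2-oxazol-3-yl on an aromatic carbon. Going by the values given here, no comparable step has been measured here, so the expectation rests only on the two values above. Both measured compounds sit at the low-toxicity end of the read-out, and exchanging one five-membered heteroaromatic ring for another is expected to leave the number essentially where it is, with no step beyond the scatter: the estimated step in this assay is a 1.3-fold lower number from compound 2 to compound 3 (0.10 log units; within the scatter). Compound 3 is therefore estimated to give 60000 nM in this assay, with a likely range from 30000 nM to 120000 nM.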

Compound 3, half-maximal cytotoxic concentration: 59000 nM
Beside the measured number, compound 3's estimate is 1.0-fold (0.01 log units) above it; low and high end bracket the measured number.
By their numbers in this assay, from the lowest: compounds 1, 3 and 2 (each within the scatter of the next).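

In this assay, exchanging the 5-isopropyl-1,2-oxazol-3-yl group for the 2-(trifluoromethyl)-1,3-thiazol-4-yl group next to the ring nitrogen gives a 1.3-fold lower number from compound 2 to compound 3 (0.10 log units; within the scatter). Going by these compounds alone, this is the first reading of a change in one place, since compound 1 differs from compound 2 in two places, and it shows that this exchange of one five-membered aromatic ring for another does not move the number beyond the scatter. The change still swaps several things at once, including the ring atoms, the point of attachment and the group carried on the ring, and nothing measured here explains the result.

From the compounds shown here alone, whether the read-out stays in the same range with a different kind of group at this position, such as a pyridine ring, a simple phenyl ring or an amine, remains open. Also open, going by these compounds, is what the bromine and the chlorine each contribute on their own, which would take two compounds that differ only in that halogen.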